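This account rests on a few compounds, and the source may have more. Where it says the series, first, only, none or still open, it means among the compounds named here.

Three compounds share a long-chain ether-bearing core joined through an ester to a phosphate-serine headgroup, and they have been tested in an assay on HEK293-A cells with putative P2Y purinoceptor 10 (Mus musculus) as the target, with a stated time of 1.5 h; on this read-out lower numbers stand for smaller maximal responses and higher numbers for larger maximal responses. Compound 1 `CCCCCCCCCCCOc1ccccc1CCC(=O)OC[C@H]1OCC=C[C@@H]1OP(=O)(O)OC[C@H](N)C(=O)O` reaches 0.071 in this assay. Compound 2 `CCCCCCCCCCCOc1ccccc1CCC(=O)OCc1ccccc1OP(=O)(O)OC[C@H](N)C(=O)O` gives 0.02 in this assay, and that number sits within the usual scatter of the value for compound 1, so the two cannot be told apart on this read-out. Compound 3 `CCCCCCCCCCCOc1ccccc1CCC(=O)OCc1ccc(OP(=O)(O)OC[C@H](N)C(=O)O)cc1` was reported in this assay as "not active" (no number reported), with no number at all. Compound 1 therefore stands among the compounds that gave a number, with its nearest neighbour, compound 2, indistinguishable from it.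

Compound 4 `CCCCCCCCCCCOc1ccccc1CCC(=O)OC[C@H]1OCC=C[C@H]1OP(=O)(O)OC[C@H](N)C(=O)O` has not yet been measured in this assay. It differs from compound 1 only in the drawn configuration of one stereocentre: the two compounds have the same atoms and bonds; at least one stereo element is drawn with a configuration in one of them and without one in the other: 1 of 4 stereo elements differ; a stereocentre at a saturated ring carbon is drawn S in compound 1 and R in compound 4. Among the compounds with values here, no step between two measured compounds in this set shows what such a change does, so there is nothing to lean on. Because compound 1 itself gives only 0.071, there is little room for a response to fall, and a rise cannot be ruled out either. The step from compound 1 to compound 4 is expected to stay within the scatter, a number 0.0010 lower from compound 1 to compound 4 (within the scatter). Compound 4 is thus estimated to reach 0.07 in this assay, between 0 and 0.16.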

Compound 4, intrinsic activity: the largest response reached, as a fraction of the reference agonist's: 0.05
For compound 4 the middle estimate is 0.020 above the measured one, and the stated range covers the measured number.
By their numbers in this assay, from the lowest: compounds 2, 4 and 1 (each within the scatter of the next).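

Within the data shown here, this pair is the first in the set to isolate a single stereocentre. In this assay, changing the saturated ring carbon from S in compound 1 to R in compound 4 gives a number 0.021 lower from compound 1 to compound 4 (within the scatter), so this stereocentre change produces no difference that this read-out can resolve, and compound 4 joins compound 1 as a compound that still gives a measurable number. One caution applies to reading the pair as a clean swap of one configuration for the other: the fact that one of compounds 1 and 4 is drawn with a defined configuration and the other without, at the place where they differ

With every number in this set so small, the compounds shown cannot say whether this stereocentre would matter in a compound giving a much larger maximal response. They also leave open what would happen if the phosphate gave way to a carboxylic acid or an amine, or if the long ether chain were replaced by a shorter chain.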